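Sulfur-bearing para substituent shrinks again in the series

A few compounds are considered here, and "the series" means these few. Any claim that something is new, unique, unknown or untested is made for them only; others in the source may bear on it.

Compound 3 `CC#C[C@H]1CN(S(=O)(=O)c2ccc(N)nc2)CCN1c1ccc(S(C)(=N)=O)cc1` holds the highest number of the three measured: in an assay on cells (Hepatocyte) for inhibition of glucokinase regulatory protein (Mus musculus), with stated times of 20 min and 40 min (a higher number here means that more compound is needed for the effect, a lower number that less compound is needed), compound 3 gives 704 nM, against 130 nM for compound 1 `C#CCC(O)(c1ccc(N2CCN(S(=O)(=O)c3ccc(N)nc3)C[C@@H]2C#CC)cc1)C(F)(F)F` and 271 nM for compound 2 `CC#C[C@H]1CN(S(=O)(=O)c2ccc(N)nc2)CCN1c1ccc(S(=O)(=O)NCC2CC2)cc1`. The steps onto compound 3, a 5.4-fold higher number from compound 1 to compound 3 (0.73 log units; beyond the scatter) and a 2.6-fold higher number from compound 2 to compound 3 (0.41 log units; beyond the scatter), both raised the number on replacing a larger group at this aromatic carbon with a smaller one. Compound 4 `CC#C[C@H]1CN(S(=O)(=O)c2ccc(N)nc2)CCN1c1ccc([S+](C)[O-])cc1` carries the change (a group of 3 heavy atoms (1 carbon, 1 oxygen, 1 sulfur; no ring) in place of a group of 4 heavy atoms (1 carbon, 1 nitrogen, 1 oxygen, 1 sulfur; no ring), on an aromatic carbon); the entering group keeps one hydrogen-bond acceptor and loses the hydrogen-bond donor. Among the compounds with values here, no measured step covers this exact swap. Given the trend shown by a 2.6-fold higher number from compound 2 to compound 3 (0.41 log units; beyond the scatter), a modest further rise or a step within the scatter is expected, a 1.4-fold higher number from compound 3 to compound 4 (0.15 log units; within the scatter). Compound 4 is therefore estimated at 1000 nM (range 400 nM to 2500 nM).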

Compound 4, half-maximal effective concentration: > 12500 nM
Compound 4 was reported as a limit; the forecaster's own chance of this, stated with the estimate: 5%; at least 12-fold (1.09 log units) between middle value and limit.
By their numbers in this assay, from the lowest: compound 1; then compound 2; then compound 3. At a limit, above all of these: compound 4.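

Compound 4 is reported only as a limit, not as a number: the limit of > 12500 nM in this assay, at which 1 of the 4 values shown sits.

On the aromatic carbon para to a large group, the earlier modest steps give way to a large one, an at least 17-fold higher number from compound 3 to compound 4 (1.24 log units; beyond the scatter), on a swap that drops the nitrogen and the hydrogen-bond donor with it. The distance to the larger groups is also large, with an at least 46-fold higher number from compound 2 to compound 4 (1.66 log units; beyond the scatter) and an at least 96-fold higher number from compound 1 to compound 4 (1.98 log units; beyond the scatter).

Going by these compounds, whether the donor or the group's size drives this stays open, since the two change together here. An amine or a primary sulfonamide at this carbon would help separate them.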